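Working notes: from compound 2 to compound 3

The source may hold more compounds than are shown below. What is called first, only, known or untested is meant among the compounds shown, and "the series" means these compounds.

Measured in a functional assay on DU-145 cells (Homo sapiens) for inhibition, read by trypan blue exclusion, with a stated time of 72 h; a lower number here means a stronger inhibitor, a higher number a weaker inhibitor:
- compound 1 `Cn1c(=O)c(S(=O)(=O)c2ccc(F)cc2F)cc2cnc(Nc3ccc4sccc4c3)nc21` gives 500 nM
- compound 2 `Cn1c(=O)c(S(=O)(=O)c2ccc(F)cc2F)cc2cnc(Nc3ccc4occc4c3)nc21` gives 15000 nM

Compound 2 stands highest of the two numbers in this assay, at 15000 nM. Compound 3 `Cn1c(=O)c(S(=O)(=O)c2ccc(F)cc2F)cc2cnc(Nc3ccc4[nH]ncc4c3)nc21` carries 1H-indazol-5-yl in place of 1-benzofuran-5-yl on a nitrogen on an aromatic ring. Within the data shown here, one measured step bears on this place: a 30-fold higher number from compound 1 to compound 2 (1.48 log units; beyond the scatter), a large one. Among the measured compounds shown here, no measurement yet covers 1H-indazol-5-yl, so the direction is uncertain. A moderate move to a lower number is expected, with an estimated 5.0-fold lower number from compound 2 to compound 3 (0.70 log units; beyond the scatter). For compound 3 the estimate is 3000 nM, within an expected range of 600 nM to 15000 nM.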

Compound 3, half-maximal inhibitory concentration: 30000 nM
For compound 3 the middle estimate is 10-fold (1.00 log units) below the measured one; measured number above the stated range.
By their numbers in this assay, from the lowest: compound 1; then compounds 2 and 3 (each within the scatter of the next).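

In this assay 1H-indazol-5-yl, which adds a hydrogen-bond donor absent from 1-benzofuran-5-yl, gives a 2.0-fold higher number from compound 2 to compound 3 (0.30 log units; within the scatter) and so does not separate these two groups on the nitrogen. Against 1-benzothiophen-5-yl it gives a 60-fold higher number from compound 1 to compound 3 (1.78 log units; beyond the scatter) and thus leaves compound 1 apart from both other compounds at this place. Nothing measured here accounts for these differences.

Still open, as far as these compounds go, is how a plain phenyl, a 1H-indol-5-yl or a quinolin-6-yl would read at this place. From the compounds shown here alone, the effect of replacing the 2,4-difluorophenyl sulfonyl group on the shared core also remains open.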